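Chain length at the amino alcohol carbon and spleen potency

A few compounds are considered here, and "the series" means these few. Any claim that something is new, unique, unknown or untested is made for them only; others in the source may bear on it.

Compound 1 `CCCCCCCOc1ccc(CCC(N)(CC)CO)cc1`: 0.059 mg/kg
Compound 2 `CCCCCCCOc1ccc(CC[C@@](N)(CO)CCC)cc1`: 0.63 mg/kg
Compound 3 `CCCCCCCOc1ccc(CC[C@](N)(CO)CCC)cc1`: > 10 mg/kg

In a functional assay on the whole organism (spleen, spleen) with Rattus norvegicus as the target (a higher number here means that more compound is needed for the effect, a lower number that less compound is needed), compound 1 gives 0.059 mg/kg and compound 2 gives 0.63 mg/kg. For compound 3 the assay reports only a limit, > 10 mg/kg, so compound 3 stands at the edge of the numbers shown rather than on a number (the limit of > 10 mg/kg in this assay, at which 1 of the 3 values shown sits). Compound 2 and compound 3 have the same atoms and bonds and differ only in configuration as drawn (the fact that compounds 2 and 3 differ only in the configuration as drawn), yet an at least 15-fold higher number from compound 2 to compound 3 (1.20 log units; beyond the scatter).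

Compound 4 `CCCCCCCOc1ccc(CCC(N)(CO)CCCC)cc1` has not been measured. Relative to compound 3, (a group of 8 heavy atoms (6 carbon, 1 nitrogen, 1 oxygen; no ring) in place of a group of 7 heavy atoms (5 carbon, 1 nitrogen, 1 oxygen; no ring), on a saturated chain carbon, two bonds along the chain from an aromatic carbon). For the measured compounds named here, two measured steps bear on this: an 11-fold higher number from compound 1 to compound 2 (1.03 log units; beyond the scatter), and an at least 160-fold higher number from compound 1 to compound 3 (2.22 log units; beyond the scatter). Both lengthenings of the chain on that carbon gave higher numbers, the drawn configuration deciding how much. Compound 4 is drawn without a defined configuration, so it is read against compound 2 as well as compound 3. A downward step from the limit of compound 3 is expected, an at least 3.3-fold lower number from compound 3 to compound 4 (0.52 log units; beyond the scatter), leaving compound 4 near or somewhat above compound 2. Compound 4 is estimated at 3 mg/kg, between 0.8 mg/kg and 10 mg/kg.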

Compound 4, dose for 50% inhibition: > 10 mg/kg
Compound 4: a limit, no number (the forecaster's own chance of this, stated with the estimate: 30%); middle value at least 3.3-fold (0.52 log units) from the limit.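

In this assay compound 4 gives only a limit, > 10 mg/kg, and not a number. On this saturated chain carbon, two bonds along the chain from an aromatic carbon, the longer chain gives an at least 15-fold higher number from compound 2 to compound 4 (1.20 log units; beyond the scatter) and an at least 160-fold higher number from compound 1 to compound 4 (2.22 log units; beyond the scatter), so a compound drawn without a defined configuration does not keep the number of compound 2, and the chain length of compound 1 still holds the lowest number shown. The step between compound 3 and compound 4 cannot be read, as both stand at the same limit: the limit of > 10 mg/kg in this assay, at which 2 of the 4 values shown sit.

As far as these compounds go, it stays open how each single configuration of compound 4 would read in this assay. From the compounds shown here alone, it also stays open whether a methyl group or a shorter chain on this carbon would give a number lower still than that of compound 1.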